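This account rests on a few compounds, and the source may have more. Where it says the series, first, only, none or still open, it means among the compounds named here.

The compounds measured in a functional assay on H184B5F5/M10 cells (Homo sapiens) for antiproliferative activity, read by XTT assay, with a stated time of 72 h; a higher number here means a weaker inhibitor, a lower number a stronger inhibitor:

Compound 1 `COc1ccc(-c2cc3ccccc3nc2/C=C/C(=O)c2ccccc2)cc1` gives 8560 nM.
Compound 2 `COc1ccc(-c2cc3ccccc3nc2/C=C/C(=O)c2ccc(F)cc2)cc1` gives > 10000 nM, which is a limit of the assay rather than a number.
Compound 3 `COc1ccc(C(=O)/C=C/c2nc3ccccc3cc2-c2ccc(OC)cc2)cc1` gives > 10000 nM, again a limit of the assay rather than a number.

Compound 3 therefore stands at the edge of what this assay can report: the evidence is the limit of > 10000 nM in this assay, at which 2 of the 3 values shown sit, so for compound 3 no exact potency is known, only that it is no stronger than that bound.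

Compound 4 `COc1ccc(-c2cc3ccccc3nc2/C=C/C(=O)c2ccc(OC)c(OC)c2)cc1` differs from compound 3 by one change: methoxy in place of hydrogen on an aromatic carbon.

Two measured steps resemble this kind of change. One is an at least 1.1-fold higher number from compound 1 to compound 2 (0.06 log units; that floor lies within the scatter), the other is an at least 1.1-fold higher number from compound 1 to compound 3 (0.06 log units; that floor lies within the scatter); both end at the limit, so their true sizes are not readable, only that neither gave a stronger inhibitor. The step that the two limits leave unreadable from compound 2 to compound 3, since both of its values are limits.

Adding a methoxy group on the same ring has so far not made a stronger inhibitor, and compound 3 already sits at the bound. The expected step that the limit leaves unreadable from compound 3 to compound 4 is thus no gain in potency, with the assay most likely reporting a limit again. Compound 4 is estimated at 15000 nM, within a range from 6000 nM to 40000 nM.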

Compound 4, half-maximal inhibitory concentration: 7240 nM
Beside the measured number, compound 4's estimate is 2.1-fold (0.32 log units) above it, and the stated range covers the measured number.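

In this assay, turning 4-methoxyphenyl into 3,4-dimethoxyphenyl gives an at least 1.3-fold lower number from compound 3 to compound 4 (0.14 log units; that floor lies within the scatter), so compound 4 has an exact number where compound 3 has only a limit, although the floor of this step does not show a real gain. The comparison with the fluoro compound reads the same way, with an at least 1.3-fold lower number from compound 2 to compound 4 (0.14 log units; that floor lies within the scatter), and both steps rest on a limit rather than on two numbers: the limit of > 10000 nM in this assay, at which 2 of the 4 values shown sit. Against the plain phenyl, the change gives a 1.2-fold lower number from compound 1 to compound 4 (0.07 log units; within the scatter), so compound 4 cannot be told apart from compound 1, which shows that a ring carrying substituents can still give a readable number here.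

Going by these compounds, the true values of compound 2 and compound 3 remain unknown, so the real size of the effect of the added methoxy group, ortho to a methoxy group, stays open. On these data alone, it is also open whether a hydroxy group or an amine in that place would give a step beyond the scatter.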